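Configuration at the ring carbon in the shared core

The source may hold more compounds than are shown below. What is called first, only, known or untested is meant among the compounds shown, and "the series" means these compounds.

Compound 1 `CN(C)[C@@H]1CC[C@@H](c2ccccc2)c2ccccc21` is the stronger of the two measured entries: in a functional assay on Hypothalamus for inhibition of Norepinephrine transporter (Rattus norvegicus) (on this read-out lower numbers stand for stronger inhibition and higher numbers for weaker inhibition), compound 1 gives 140 nM, while compound 2 `CN[C@H]1CC[C@@H](c2ccc(Oc3ccccc3)cc2)c2ccccc21` gives 3900 nM, a gap that lies beyond the scatter. Compound 3 `CN(C)[C@H]1CC[C@@H](c2ccccc2)c2ccccc21` is not yet measured. It relates to compound 1 thus: the two compounds have the same atoms and bonds and differ only in configuration as drawn: 1 of 2 stereo elements differ; a stereocentre at a saturated ring carbon is drawn R in compound 1 and S in compound 3. Among the compounds with values here, no such stereochemical step between measured compounds is available, so the expectation rests on the change alone. A step from compound 1 to compound 3 toward a higher number, of moderate size, is expected, a 3.6-fold higher number from compound 1 to compound 3 (0.55 log units; beyond the scatter). Compound 3 is therefore estimated at 500 nM, within 100 nM to 3000 nM.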

Compound 3, half-maximal inhibitory concentration: 310 nM
Compound 3: middle estimate off by 1.6-fold (0.21 log units), on the high side; low and high end bracket the measured number.
By their numbers in this assay, from the lowest: compound 1; then compound 3; then compound 2.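

Inverting the saturated ring carbon from R to S gives the first stereochemical step in the series in this assay: a 2.2-fold higher number from compound 1 to compound 3 (0.35 log units; beyond the scatter). The configuration at this position therefore moves the number beyond the scatter, but only modestly, and the S form keeps inhibition in the same range as the R form. With no atom or bond changing, the shift belongs to this stereocentre alone: the fact that compounds 1 and 3 differ only in the configuration as drawn

As far as these compounds go, the effect of inverting the other stereo element remains open. So does whether a primary amine in place of the dimethylamino group would show a step of similar size.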